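This account rests on a few compounds, and the source may have more. Where it says the series, first, only, none or still open, it means among the compounds named here.

Values in a functional assay on HCT-116 cells (Homo sapiens) for cytotoxicity, read by MTT assay (on this read-out higher numbers stand for weaker inhibition and lower numbers for stronger inhibition), for the series so far
- compound 1 (`Cc1cc(O)c(C(=O)/C=C/c2ccc(Cl)cc2)c(=O)o1`) gives 87400 nM as a number
- compound 2 (`COc1ccc(/C=C/C(=O)c2c(O)cc(C)oc2=O)cc1`) gives > 100000 nM as a limit
- compound 3 (`COc1ccc(/C=C/C(=O)c2c(O)cc(C)oc2=O)c(OC)c1`) gives > 100000 nM as a limit

Compound 2 is known only as a limit, and compound 3 shares that position (the limit of > 100000 nM in this assay, at which 2 of the 3 values shown sit). Compound 4 (`Cc1cc(O)c(C(=O)/C=C/c2ccc(-c3ccccc3)cc2)c(=O)o1`) carries phenyl in place of methoxy on an aromatic carbon, para to a large group (phenyl in place of methoxy on an aromatic carbon). Among the compounds with values here, two measured steps bear on this change. Going from chloro to methoxy gives an at least 1.1-fold higher number from compound 1 to compound 2 (0.05 log units; that floor lies within the scatter) and sets only a floor inside the scatter. Adding a second methoxy gives a step that the two limits leave unreadable from compound 2 to compound 3 and sets no size. Neither step supplies a size for this change, so no step beyond the scatter is expected in this assay in either direction. The expected step is an at least 1.2-fold lower number from compound 2 to compound 4 (0.09 log units; that floor lies within the scatter) and remains an estimate only. Compound 4 is estimated at 80000 nM with an expected range of 30000 nM to 150000 nM on this read-out.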

Compound 4, half-maximal inhibitory concentration: > 100000 nM
Compound 4 gave a limit, no number (the forecaster's own chance of this, stated with the estimate: 50%); middle value at least 1.2-fold (0.09 log units) from the limit.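

In this assay compound 4 gives > 100000 nM, a limit and not a number, so phenyl on this aromatic carbon, para to a large group, yields no readable value, as with methoxy. Phenyl in place of chloro gives an at least 1.1-fold higher number from compound 1 to compound 4 (0.05 log units; that floor lies within the scatter), which is only a floor, and the steps between two limits cannot be read. Even a six-membered aromatic ring here leaves the series without a new number: the limit of > 100000 nM in this assay, at which 3 of the 4 values shown sit.

The compounds shown leave open whether any group at this position gives a step beyond the scatter. An amine or a carboxylic acid here would be the next test of that.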